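Trading a Sulfonamide for an Amide on a Shared Core

This account rests on a few compounds, and the source may have more. Where it says the series, first, only, none or still open, it means among the compounds named here.

For the measured compounds named here, compound 1 `COc1ccc(-c2cc(-c3ccc(S(=O)(=O)N(C)C)cc3)cnc2N)cn1` is one of two compounds measured in a physicochemical assay for solubility, read by nephelometry, in phosphate buffer, measured as kinetic solubility, at pH 6.5; on this read-out lower numbers stand for lower solubility and higher numbers for higher solubility. In this assay compound 1 gives 6.3 ug/mL, the lower of the two numbers. Compound 2 `COc1ccc(-c2cc(-c3ccc(S(C)(=O)=O)cc3C(F)(F)F)cnc2N)cn1` gives 12.5 ug/mL in this assay, and the gap between the two lies within the scatter, so the two values are not distinguished from each other. Compound 3 `COc1ccc(-c2cc(-c3ccc(C(=O)N(C)C)cc3)cnc2N)cn1` has not yet been measured in this assay. It is related to compound 1 by a single change: dimethylcarbamoyl in place of dimethylsulfamoyl on an aromatic carbon. Going by the values given here, no step between two measured compounds shows what such a change does to this read-out, so any expectation rests on the value of compound 1 alone. The change is expected to amount to a 1.3-fold higher number from compound 1 to compound 3 (0.10 log units; within the scatter), a step that stays within the scatter and has no clear direction. Compound 3 is therefore estimated at 8 ug/mL in this assay, within a range from 3 ug/mL to 25 ug/mL.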

Compound 3, solubility: > 100 ug/mL
Compound 3: only a limit was reported; the forecaster's own chance of this, stated with the estimate: 5%; middle value at least 12-fold (1.09 log units) away from the limit.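

For the compounds shown here, on the aromatic carbon para to a large group, dimethylcarbamoyl in place of dimethylsulfamoyl gives an at least 15-fold higher number from compound 1 to compound 3 (1.20 log units; beyond the scatter) in this assay, and this is the first readable step for this change, which the earlier pair of compounds could not supply. Compound 3 reads > 100 ug/mL, which is a limit of the assay and not a number. The size of the step therefore stands only as a minimum, with its upper end open: the limit of > 100 ug/mL in this assay, at which 1 of the 3 values shown sits.

From the compounds shown here alone, this change is seen in a single pair on the shared core, so whether it would repeat on another core remains open. Also open, going by these compounds, is what a primary carboxamide, a morpholine amide or a carboxylic acid on the same aromatic carbon would read in this assay.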